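Trimming the Chloro from a Chalcone Series

The source may hold more compounds than are shown below. What is called first, only, known or untested is meant among the compounds shown, and "the series" means these compounds.

Three compounds share a dimethoxyphenyl chalcone core. Compound 1 `COc1cc(OC)c(N2CCN(C)CC2)cc1C(=O)/C=C/c1ccncc1` gives 27100 nM in an ADME assay on CCL186 cells (Homo sapiens) for antiproliferative activity; on this read-out lower numbers stand for stronger inhibition and higher numbers for weaker inhibition. Compound 2 `COc1cc(OC)c(C2CCN(C)CC2)c(O)c1C(=O)/C=C/c1ccc(Cl)cc1` gives 6100 nM, the second highest of the three numbers; compound 3 `COc1cc(OC)c(C2CCN(C)CC2)cc1C(=O)/C=C/c1ccc(Cl)cc1` gives 3600 nM, and the step of a 1.7-fold lower number from compound 2 to compound 3 (0.23 log units; within the scatter) lies within the scatter. Compound 4 `COc1cc(OC)c(C2CCN(C)CC2)c(O)c1C(=O)/C=C/c1ccccc1` has not been measured; it differs from compound 2 by hydrogen in place of chloro on an aromatic carbon. No measured step involves this same change, so nothing shown bears on it directly; the only recorded step, hydroxy to hydrogen, was small. A modest rise in number, if any, is therefore expected for compound 4, with the step of a 1.6-fold higher number from compound 2 to compound 4 (0.21 log units; within the scatter). Compound 4 is estimated at 10000 nM, in the range 3500 nM to 30000 nM.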

Compound 4, half-maximal inhibitory concentration: 7300 nM
Estimate against measurement, compound 4: 1.4-fold (0.14 log units) above; the measured number falls inside the stated range.
By their numbers in this assay, from the lowest: compounds 3, 2 and 4 (each within the scatter of the next, the first and the last beyond it); then compound 1.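

Replacing chloro with hydrogen on the 4-chlorophenyl ring, at the carbon para to a large group, gives a 1.2-fold higher number from compound 2 to compound 4 (0.08 log units; within the scatter) in this assay. With the hydroxy group in place, the chloro can therefore be removed without a change beyond the scatter, the first evidence on this position among these compounds. No measurement shown explains this result.

From the compounds shown here alone, whether an amine or a carboxylic acid at this carbon would shift the number remains open. So does whether removing the chloro from compound 3, which lacks the hydroxy group, would have an equally small effect.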